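From 4-methylbenzyl to 3-fluorobenzyl on a shared core

The source may hold more compounds than are shown below. What is called first, only, known or untested is meant among the compounds shown, and "the series" means these compounds.

Compound 1 `CC(C)[C@@H](CO)n1cc(C(=O)O)c(=O)c2c(O)c(Cc3cccc(Cl)c3F)ccc21`: 125000 nM
Compound 2 `Cc1ccc(Cn2cc(C(=O)O)c(=O)c3c(O)c(Cc4cccc(Cl)c4F)ccc32)cc1`: 256000 nM

In an ADME assay on C8166 cells (Homo sapiens) for cytotoxicity, read by MTT assay (a higher number here means that more compound is tolerated, a lower number that less compound is tolerated), compound 2 holds the higher of the two numbers, at 256000 nM. The next compound to consider, compound 3 `O=C(O)c1cn(Cc2cccc(F)c2)c2ccc(Cc3cccc(Cl)c3F)c(O)c2c1=O`, keeps the shared core and differs from it by 3-fluorophenyl in place of 4-methylphenyl on a saturated chain carbon bound to an aromatic nitrogen. This places 3-fluorophenyl in place of 4-methylphenyl on a saturated chain carbon bound to an aromatic nitrogen, which also reads as 4-methylbenzyl to 3-fluorobenzyl.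

Among the measured compounds shown here, only one measured step bears on this change, and only indirectly. That step is a 2.0-fold higher number from compound 1 to compound 2 (0.31 log units; beyond the scatter), a modest one, with 4-methylbenzyl in place of 1-(hydroxymethyl)-2-methylpropyl on an aromatic nitrogen. For the measured compounds named here, no measured pair exchanges one benzyl group for another. Compound 2 and compound 3 both carry a benzyl group at this place, and the modest size of a 2.0-fold higher number from compound 1 to compound 2 (0.31 log units; beyond the scatter) suggests that no step beyond the scatter should be expected in this assay. The expected change is a 1.2-fold lower number from compound 2 to compound 3 (0.07 log units; within the scatter). For compound 3 the estimated value is 220000 nM, with an expected range of 110000 nM to 400000 nM.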

Compound 3, half-maximal cytotoxic concentration: 69000 nM
Estimate against measurement, compound 3: 3.2-fold (0.50 log units) above; the whole stated range lies above it.
By their numbers in this assay, from the lowest: compounds 3 and 1 (each within the scatter of the next); then compound 2.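

In this assay the exchange of one benzyl group for another proves not to be neutral: 3-fluorophenyl in place of 4-methylphenyl on a saturated chain carbon bound to an aromatic nitrogen gives a 3.7-fold lower number from compound 2 to compound 3 (0.57 log units; beyond the scatter), so a benzyl group at this place does not by itself hold the number near that of compound 2. Set against the branched chain of compound 1, 3-fluorobenzyl gives a 1.8-fold lower number from compound 1 to compound 3 (0.26 log units; within the scatter), and with that step inside the scatter, only 4-methylbenzyl stands apart among these three compounds, while the division between a benzyl group and the branched chain does not separate the numbers. No measurement available here accounts for the difference between the two benzyl groups.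

The two benzyl groups differ both in the substituent and in where it sits, and the compounds shown do not tell these two changes apart: 3-methylbenzyl or 4-fluorobenzyl would each alter only one of them. They also leave open whether the high number of compound 2 is particular to the methyl group or is shared by unsubstituted benzyl or 4-methoxybenzyl.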